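The source may report more compounds than this note shows. Statements on the series, on what has been measured and on what is new or still open speak of the compounds shown alone.

Compound 1 `O=Cc1ccc(-c2cn3ccnc3c(-c3ccc4ncn(C5CCCCC5)c4c3)n2)cc1` gives 5.11% in a functional assay on SK-OV-3 cells (Homo sapiens) for inhibition, read by sulforhodamine B assay, with a stated time of 48 h, tested at 10 uM; a lower number here means less inhibition, a higher number more inhibition at the concentration tested (going by the name of the read-out).
Compound 2 `Brc1ccc(-c2cn3ccnc3c(-c3ccc4ncn(C5CCCCC5)c4c3)n2)cc1` gives 6.44% in this assay.

For the measured compounds named here, compound 2 stands highest of these two numbers, with compound 1 nearest; the sole measured step, a number 1.3 percentage points higher from compound 1 to compound 2 (within the scatter), lies within the scatter. Compound 3 `COc1ccccc1-c1cn2ccnc2c(-c2ccc3ncn(C4CCCCC4)c3c2)n1` differs from compound 2 by 2-methoxyphenyl in place of 4-bromophenyl on an aromatic carbon. Going by the values given here, only that one step bears on this change, a swap at the same aromatic carbon, and it was small. Compound 3 is therefore expected to show a step of a number 0.6 percentage points higher from compound 2 to compound 3 (within the scatter), not beyond the scatter, and its value is estimated at 7%, within 0% to 18%.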

Compound 3, a percentage reported as inhibition, at one concentration (the size of the read-out at that concentration, not a potency): 10.6%
Estimate against measurement, compound 3: 3.6 percentage points below; measured number inside the range.
By their numbers in this assay, from the lowest: compounds 1, 2 and 3 (each within the scatter of the next).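

Two new steps bear on this aromatic carbon: a number 4.2 percentage points higher from compound 2 to compound 3 (within the scatter) for 2-methoxyphenyl in place of 4-bromophenyl, and a number 5.5 percentage points higher from compound 1 to compound 3 (within the scatter) for 2-methoxyphenyl in place of 4-formylphenyl. The three aryl groups, now including the oxygen-bearing 2-methoxyphenyl, all lie within the scatter of one another in this assay and none separates from the others. Whether an amine or a carboxylic acid on the phenyl ring at this carbon would give a step beyond the scatter stays open, and no measurement shown speaks to what lies behind these close numbers.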